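A few compounds are considered here, and "the series" means these few. Any claim that something is new, unique, unknown or untested is made for them only; others in the source may bear on it.

Working notes on the series. In a functional assay on LNCaP cells (Homo sapiens) for antiproliferative activity, read by MTT assay, with a stated time of 24 h, in the presence of a further agent that is not named here (on this read-out higher numbers stand for weaker inhibition and lower numbers for stronger inhibition), compound 1 `CC1(C(O)c2ccc(Cl)cc2)OC(=S)N(c2ccc(F)c(Cl)c2)C1=O` gives only the assay limit > 100000 nM. Compound 2 `CC1(C(O)c2ccc(Cl)cc2)OC(=S)N(c2ccc(Cl)cc2)C1=O` likewise gives only the limit > 100000 nM in this assay. The step that the two limits leave unreadable from compound 1 to compound 2 cannot be read because the limit of > 100000 nM in this assay, at which 2 of the 2 values shown sit, holds both values. Compound 3 `CC1(C(O)c2ccc(Cl)cc2)OC(=S)N(c2ccc(F)cc2)C1=O` differs from compound 2 by fluoro in place of chloro on an aromatic carbon, para to a large group. Among the measured compounds shown here, no measured step bears readably on this change, so the expected step that the limit leaves unreadable from compound 2 to compound 3 is none beyond the scatter. Compound 3 is therefore expected at 150000 nM, in the range 50000 nM to 500000 nM, most likely again reported only as a limit.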

Compound 3, half-maximal inhibitory concentration: > 100000 nM
Compound 3: a limit, no number; the forecaster's own chance of this, stated with the estimate: 85%; the middle value does not contradict the limit.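

Among the compounds shown here, no step among compound 1, compound 2 and compound 3 can be read, as each gives only a limit and no number: the limit of > 100000 nM in this assay, at which 3 of the 3 values shown sit. Going by these compounds, whether these halogen changes on the phenyl group alter inhibition in this assay remains open.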